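Silyl ether in place of acetate on the shared core

The source may hold more compounds than are shown below. What is called first, only, known or untested is meant among the compounds shown, and "the series" means these compounds.

Compound 2 `COc1ccc(C2=C(c3cc(OC)c(OC)c(OC)c3)C(=O)C(OC(C)=O)C2)cc1` carries an acetyl on an oxygen on a saturated carbon of the shared core; in an ADME assay on HEK293 cells (Homo sapiens) for cytotoxicity, read by MTT assay, with a stated time of 72 h (on this read-out lower numbers stand for stronger inhibition and higher numbers for weaker inhibition), compound 2 gives "not determined" (no result reported), so it has no number of its own to stand on. Two neighbours on the same core are measured. In this assay compound 1 `COc1ccc(C2=C(c3cc(OC)c(OC)c(OC)c3)C(=O)C(OC(C)=O)C2)cc1Cl` gives 60 ug/mL. For compound 3 `COc1ccc(C2=C(c3cc(OC)c(OC)c(OC)c3)C(=O)C(OC(C)=O)C2)cc1OC(C)C` this assay reports only a limit, > 100 ug/mL. Going by the values given here, the single measured step, an at least 1.6-fold higher number from compound 1 to compound 3 (0.22 log units; that floor lies within the scatter), alters a substituent on an aromatic carbon and does not touch the place changed here. Compound 4 `COc1ccc(C2=C(c3cc(OC)c(OC)c(OC)c3)C(=O)C(O[SiH2]C(C)(C)C)C2)cc1` differs from compound 2 by a group of 5 heavy atoms (4 carbon, 1 silicon; no ring) in place of a group of 3 heavy atoms (2 carbon, 1 oxygen; no ring), on an oxygen on a saturated carbon. Among the compounds with values here, no measured step bears on this exchange, so no direction beyond the scatter in this assay can be derived. For compound 4 the expected value in this assay is estimated at 70 ug/mL, within 30 ug/mL to 150 ug/mL, with a real chance of a limit like (the limit of > 100 ug/mL in this assay, at which 1 of the 3 values shown sits).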

Compound 4, half-maximal inhibitory concentration: > 100 ug/mL
Compound 4: a limit, no number; the forecaster's own chance of this, stated with the estimate: 45%; at least 1.4-fold (0.15 log units) between middle value and limit.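

No step can be read between compound 2 and compound 4. In this assay compound 4 gives > 100 ug/mL, which is a limit. The compounds shown leave open how exchanging the acetyl on that oxygen shifts this read-out.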